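The source may hold more compounds than are shown below. What is called first, only, known or untested is meant among the compounds shown, and "the series" means these compounds.

Of the compounds shown here, three have been tested in a functional assay on MDA-MB-231 cells (Homo sapiens) for antiproliferative activity, read by MTT assay, with a stated time of 24 h; on this read-out lower numbers stand for stronger inhibition and higher numbers for weaker inhibition.

Compound 1 `Cc1ccccc1NNC(=O)c1ccc(NS(=O)(=O)c2cnc(O)nc2O)cc1` gives > 20000 nM, which is a limit of the assay and not a number.
Compound 2 `Cc1cccc(NNC(=O)c2ccc(NS(=O)(=O)c3cnc(O)nc3O)cc2)c1` gives > 20000 nM, again a limit rather than a number.
Compound 3 `Cc1ccccc1NNC(=O)c1cccc(NS(=O)(=O)c2cnc(O)nc2O)c1` gives > 20000 nM, also a limit and not a number.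

Compound 4 `Cc1cccc(NNC(=O)c2cccc(NS(=O)(=O)c3cnc(O)nc3O)c2)c1` has not yet been measured. Compound 1 and compound 2 differ by a single change, (3-methylphenyl in place of 2-methylphenyl on an amine nitrogen). The step this change made, a step that the two limits leave unreadable from compound 1 to compound 2, cannot be read in size, as the two limits leave it open. The difference between the core of compound 1 and the core of compound 3 is not broken down here. Compound 3 and compound 4 differ by the same change, (3-methylphenyl in place of 2-methylphenyl on an amine nitrogen), at the same place. Beside that unreadable step, the expected step that the limit leaves unreadable from compound 3 to compound 4 in this assay rests on (the limit of > 20000 nM in this assay, at which 3 of the 3 values shown sit), at which every value so far sits, so compound 4 is expected to remain at that limit as well. Compound 4 is estimated at 30000 nM, between 15000 nM and 100000 nM, and is expected most likely to be reported only as a limit.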

Compound 4, half-maximal inhibitory concentration: > 20000 nM
Compound 4: only a limit was reported; the forecaster's own chance of this, stated with the estimate: 85%; the middle value lies beyond the limit too.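

In this assay, among the compounds shown here, compound 3 and compound 4 both stop at a limit of the assay rather than a number, so no step between them can be read. The compounds shown leave open whether 3-methylphenyl in place of 2-methylphenyl changes activity at all, and how they rank, since every result stays at one limit: the limit of > 20000 nM in this assay, at which 4 of the 4 values shown sit.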